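The source may report more compounds than this note shows. Statements on the series, on what has been measured and on what is new or still open speak of the compounds shown alone.

Compound 2, `CC(C)c1c(C(=O)NCC2CCCCC2)nn(-c2ccc(F)cc2)c1OC[C@@H](O)C[C@@H](O)CC(=O)O`, is one of three members of a shared core that have been tested in an assay on microsomes from liver for inhibition of 3-hydroxy-3-methylglutaryl-coenzyme A reductase (Rattus norvegicus); on this read-out lower numbers stand for stronger inhibition and higher numbers for weaker inhibition. In that assay compound 2 gives 17 nM, the highest of the three numbers. Compound 1, `CC(C)c1c(C(=O)N(C)Cc2ccccc2)nn(-c2ccc(F)cc2)c1OC[C@@H](O)C[C@@H](O)CC(=O)O`, gives 5.2 nM in this assay, and compound 3, `Cc1cccc(CNC(=O)c2nn(-c3ccc(F)cc3)c(OC[C@@H](O)C[C@@H](O)CC(=O)O)c2C(C)C)c1`, gives 4.9 nM. The steps that link them are a 3.3-fold higher number from compound 1 to compound 2 (0.51 log units; beyond the scatter), a 1.1-fold lower number from compound 1 to compound 3 (0.03 log units; within the scatter) and a 3.5-fold lower number from compound 2 to compound 3 (0.54 log units; beyond the scatter).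

Compound 4, `COCc1cccc(CNC(=O)c2nn(-c3ccc(F)cc3)c(OC[C@@H](O)C[C@@H](O)CC(=O)O)c2C(C)C)c1`, has not been measured. It differs from compound 2 in one place: 3-(methoxymethyl)phenyl in place of cyclohexyl on a saturated chain carbon bound to an amide-type nitrogen. The step that bears most directly on this change is a 3.5-fold lower number from compound 2 to compound 3 (0.54 log units; beyond the scatter), where a 3-methylphenyl also replaced the cyclohexyl at the same place. The step of a 3.3-fold higher number from compound 1 to compound 2 (0.51 log units; beyond the scatter) points the same way, since the aromatic group of compound 1 gave the lower number. Among the compounds with values here, compound 4 carries a 3-(methoxymethyl)phenyl rather than the 3-methylphenyl of compound 3, and no measured pair shows what that further difference does, so the expectation rests on the aromatic-for-cyclohexyl exchange alone.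

Compound 4 is therefore expected to give a lower number than compound 2 in this assay, with the step of a 2.8-fold lower number from compound 2 to compound 4 (0.45 log units; beyond the scatter) estimated from the pattern above. The estimate for compound 4 is 6 nM, with a range from 2.5 nM to 15 nM.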

Compound 4, half-maximal inhibitory concentration: 31 nM
Estimate against measurement, compound 4: 5.2-fold (0.71 log units) below; measured number outside the range, above it.
By their numbers in this assay, from the lowest: compounds 3 and 1 (each within the scatter of the next); then compounds 2 and 4 (each within the scatter of the next).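

In this assay, the exchange of cyclohexyl for 3-(methoxymethyl)phenyl on a saturated chain carbon bound to an amide-type nitrogen gives a 1.8-fold higher number from compound 2 to compound 4 (0.26 log units; within the scatter), so an aromatic ring at this place does not by itself bring the lower number seen with the 3-methylphenyl group of compound 3. What separates the two aromatic groups is a single change, methoxy in place of hydrogen on a saturated chain carbon bound to an aromatic carbon, which gives a 6.3-fold higher number from compound 3 to compound 4 (0.80 log units; beyond the scatter), and the exchange from the benzyl(methyl)amino group of compound 1 gives a step in the same direction, a 6.0-fold higher number from compound 1 to compound 4 (0.78 log units; beyond the scatter). The compounds shown come with no measurement that would explain these steps.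

They leave open whether the higher number of compound 4 follows from the oxygen atom or from the longer chain on the ring, which a 3-propylphenyl group, with carbon in place of that oxygen, or a 3-(hydroxymethyl)phenyl group would help to separate. They also leave open how a methoxy group bound directly to the aromatic ring would compare with the methoxymethyl group of compound 4.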